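The source may hold more compounds than are shown below. What is called first, only, known or untested is meant among the compounds shown, and "the series" means these compounds.

Of the compounds shown here, three built on one shared core have been measured in a functional assay on cells (Tumor Cell line, Homo sapiens) for cytotoxicity; on this read-out lower numbers stand for stronger inhibition and higher numbers for weaker inhibition. Compound 1 `CN(C)Cc1cc(C(=O)/C=C/c2ccccc2Cl)cc(CN(C)C)c1O` gives 9550 nM. Compound 2 `CN(C)Cc1cc(C(=O)/C=C/c2ccc(Cl)cc2Cl)cc(CN(C)C)c1O` gives 3090 nM, and compound 3 `CN(C)Cc1cc(C(=O)/C=C/c2ccc(Cl)c(Cl)c2)cc(CN(C)C)c1O` gives 2350 nM. Compound 2 therefore stands second highest of the three numbers, with compound 3 within the scatter of it and compound 1 clearly higher. The step of a 3.1-fold lower number from compound 1 to compound 2 (0.49 log units; beyond the scatter) is a modest one, and the step of a 4.1-fold lower number from compound 1 to compound 3 (0.61 log units; beyond the scatter) is likewise modest, while a 1.3-fold lower number from compound 2 to compound 3 (0.12 log units; within the scatter) lies within the scatter.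

Compound 4 `CN(C)Cc1cc(C(=O)/C=C/c2ccc([N+](=O)[O-])cc2)cc(CN(C)C)c1O` has not yet been measured. It differs from compound 2 in one place: 4-nitrophenyl in place of 2,4-dichlorophenyl on a double-bonded chain carbon bound to a double-bonded chain carbon. For the measured compounds named here, none of the measured steps exchanges a chlorine-bearing ring for a nitro-bearing one, so no direct guide exists. The measured steps only show that altering the ring on the chain shifts the result by modest amounts, and that compound 1, carrying 2-chlorophenyl, gave the highest number. A change of modest size in either direction is therefore expected, with a somewhat higher number the more likely outcome. The estimate for compound 4 in this assay is 5000 nM, with a range from 1500 nM to 16000 nM, which is expected to correspond to a step of a 1.6-fold higher number from compound 2 to compound 4 (0.21 log units; within the scatter).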

Compound 4, half-maximal inhibitory concentration: 8910 nM
Compound 4: the middle estimate sits 1.8-fold (0.25 log units) below what was measured, within the range that was stated.
By their numbers in this assay, from the lowest: compounds 3 and 2 (each within the scatter of the next); then compounds 4 and 1 (each within the scatter of the next).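

In this assay, for the compounds shown here, the earlier compounds only varied where chlorine sits on the ring, and this result shows what happens when the ring at this chain carbon carries no chlorine at all. Putting 4-nitrophenyl in place of a dichlorophenyl ring moves the number up beyond the scatter in both available comparisons (a 2.9-fold higher number from compound 2 to compound 4 (0.46 log units; beyond the scatter)) and (a 3.8-fold higher number from compound 3 to compound 4 (0.58 log units; beyond the scatter)), whereas putting it in place of 2-chlorophenyl makes no readable difference (a 1.1-fold lower number from compound 1 to compound 4 (0.03 log units; within the scatter)). Across these four compounds, the two dichlorophenyl rings therefore form one group with lower numbers and the two rings bearing a single group form another with higher numbers, although no measured property is available to explain this split.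

Going by these compounds, what remains open is whether this split depends on having two chlorines or on the kind of group attached, since the nitro group and the chlorines change together here. A 4-chlorophenyl ring, an unsubstituted phenyl ring, or a ring bearing an amine or a methoxy group at this place would help to separate those two readings.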